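The compounds below may be only part of what the source reports. "The series", "measured", "known", "first", "only" and "open" are said of these compounds alone.

Compound 1 `CCCSc1nc(N/N=C(\C)c2ccccc2O)c2nnn(Cc3ccccc3Cl)c2n1` carries a 2-chlorobenzyl group on the shared core, while compound 2 `COc1cc(/C=N/Nc2nc(SCc3ccccc3)nc3c2nnn3Cc2ccccc2)cc(OC)c1OC` carries a benzyl group and a different arm on the same core. In a functional assay on ECa-109 cells (Homo sapiens) for antiproliferative activity, read by MTT assay, with a stated time of 72 h (on this read-out higher numbers stand for weaker inhibition and lower numbers for stronger inhibition), compound 1 gives only a limit, > 64000 nM, which is a boundary of the measurement rather than a number. This is the limit of > 64000 nM in this assay, at which 1 of the 2 values shown sits. In this assay compound 2 gives 4400 nM. Compound 1 therefore stands at the weak end of what has been measured, without a firm number of its own. Compound 3 `CCCSc1nc(N/N=C(\C)c2ccccc2O)c2nnn(Cc3ccccc3)c2n1` differs from compound 1 in one place: hydrogen in place of chloro on an aromatic carbon. Among the compounds with values here, no measured pair shows that single change on its own, so no measured step sets the expectation. In this assay the expected step is a number no higher from compound 1 to compound 3 (the limit leaves the size open), none beyond the usual scatter. Compound 3 is estimated at 64000 nM, within 20000 nM to 200000 nM, and may well again return only a limit.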

Compound 3, half-maximal inhibitory concentration: 11100 nM
The estimate for compound 3 lay 5.8-fold (0.76 log units) above the measured number; the measured number lies below the stated range.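

Within the data shown here, this is the first measured pair that differs only at this position, with the rest of the molecule unchanged. In this assay, replacing chloro with hydrogen on the aromatic ring, turning 2-chlorobenzyl into benzyl, gives an at least 5.7-fold lower number from compound 1 to compound 3 (0.76 log units; beyond the scatter), and a lower number here means stronger inhibition, so in this pair the chloro does not help and removing it goes with a clear gain. The step starts from a limit rather than a number, so only its minimum size is known and its true size stays open: the limit of > 64000 nM in this assay, at which 1 of the 3 values shown sits.

From the compounds shown here alone, whether a fluoro or a methyl group in the same place would behave like hydrogen or like chloro remains open. So does whether the same change would have a similar effect with a different arm on the shared core, such as the one in compound 2.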